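Bromo to carbamoyl: a cytotoxicity estimate

A few compounds are considered here, and "the series" means these few. Any claim that something is new, unique, unknown or untested is made for them only; others in the source may bear on it.

Of the compounds shown here, two have been measured so far in an ADME assay on HEp-2 cells (Homo sapiens) for cytotoxicity; on this read-out higher numbers stand for lower toxicity in this test and lower numbers for higher toxicity in this test. Compound 1 (`CC(C)CCn1c(Cn2c(=O)n(C(C)C)c3ccccc32)nc2cc(Br)ccc21`) gives 18100 nM and holds the higher number of the pair. Compound 2 (`CC(=O)c1ccc2c(c1)nc(Cn1c(=O)n(C)c3ccccc31)n2CCC(C)C`) gives 5200 nM as its number, which is lower by more than the usual scatter. The next compound to be tested is compound 3 (`CC(C)CCn1c(Cn2c(=O)n(C(C)C)c3ccccc32)nc2cc(C(N)=O)ccc21`), which has carbamoyl in place of bromo on an aromatic carbon of compound 1 (carbamoyl in place of bromo on an aromatic carbon). Within the data shown here, no two measured compounds differ in one place only, so nothing measured so far shows directly how large such a swap might be in this assay for this series. With so little evidence, the expected outcome is no change beyond the scatter, with a slight lean towards a higher number: an estimated 1.4-fold higher number from compound 1 to compound 3 (0.14 log units; within the scatter) for this swap. For compound 3 the estimated value is 25000 nM (expected range 7000 nM to 80000 nM).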

Compound 3, half-maximal cytotoxic concentration: 23400 nM
Compound 3: middle estimate off by 1.1-fold (0.03 log units), on the high side; the measured number falls inside the stated range.
By their numbers in this assay, from the lowest: compound 2; then compounds 1 and 3 (each within the scatter of the next).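

In this assay, putting carbamoyl in place of bromo on this aromatic carbon gives a 1.3-fold higher number from compound 1 to compound 3 (0.11 log units; within the scatter), the first direct measure of a change in one place in this series. Carbamoyl brings 3 heavy atoms, 1 hydrogen-bond donor and 1 hydrogen-bond acceptor where bromo had 1 heavy atom and neither donor nor acceptor, yet the two compounds cannot be told apart in this test. Nothing available explains this result.

This single pair leaves open whether a carboxylic acid or an amine on the same aromatic carbon would also stay within the scatter of compound 1. It also leaves open whether the same swap would give a similar result with a longer chain in place of the isopentyl-type chain on the shared core.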